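This account rests on a few compounds, and the source may have more. Where it says the series, first, only, none or still open, it means among the compounds named here.

Of the compounds shown here, three sharing one core have been measured. In an assay on HEK293 cells for binding affinity to 5-hydroxytryptamine receptor 7 (Homo sapiens), read by radioligand binding (on this read-out lower numbers stand for stronger inhibition and higher numbers for weaker inhibition), compound 1 `CN1CCCN(CCn2ccc3cc(Br)ccc32)CC1` gives 88 nM. Compound 2 `CN1CCCN(CCn2ccc3ccc(Cl)cc32)CC1` gives 34 nM in this assay, the second highest of the three numbers, and compound 3 `CN1CCCN(CCn2ccc3ccc(C(F)(F)F)cc32)CC1` gives 23 nM. The step from compound 2 to compound 3, trifluoromethyl in place of chloro on an aromatic carbon, was a 1.5-fold lower number from compound 2 to compound 3 (0.17 log units; within the scatter). Compound 4 `Cc1ccc2ccn(CCN3CCCN(C)CC3)c2c1` differs from compound 2 by methyl in place of chloro on an aromatic carbon. For the measured compounds named here, only that one measured step bears on a change at this carbon, and it stayed within the scatter; compound 1 differs from compound 2 in more than one place and offers no direct comparison. Compound 4 is therefore expected to give about 50 nM in this assay, with a range from 20 nM to 130 nM. The expected step of a 1.5-fold higher number from compound 2 to compound 4 (0.17 log units; within the scatter) would sit within the scatter.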

Compound 4, inhibition constant: 125 nM
Compound 4: middle estimate off by 2.5-fold (0.40 log units), on the low side; low and high end bracket the measured number.
By their numbers in this assay, from the lowest: compounds 3 and 2 (each within the scatter of the next); then compounds 1 and 4 (each within the scatter of the next).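

In this assay, this carbon proved sensitive to the group placed on it: methyl in place of chloro gave a 3.7-fold higher number from compound 2 to compound 4 (0.57 log units; beyond the scatter), and methyl in place of trifluoromethyl gave a 5.4-fold higher number from compound 3 to compound 4 (0.74 log units; beyond the scatter). The earlier swap of chloro for trifluoromethyl had stayed within the scatter, so only now does a change here move the number beyond it. Nothing shown explains this difference.

The compounds shown leave open how a methoxy, a nitrile or a fluoro group on this carbon would read. They also leave open whether methyl in place of bromo in compound 1 would raise the number too.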